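A few compounds are considered here, and "the series" means these few. Any claim that something is new, unique, unknown or untested is made for them only; others in the source may bear on it.

Of the compounds shown here, three built on one shared core have been tested in a functional assay on A-375 cells (Homo sapiens) for cytotoxicity, read by MTT assay, with a stated time of 72 h; a lower number here means a stronger inhibitor, a higher number a weaker inhibitor. Compound 1, `CN1CCN(CCCCCCn2c3c(c4ccccc42)C(=O)c2c[n+]([O-])c4ccccc4c2C3=O)CC1`, gives 630 nM in this assay. Compound 2, `CC1(C)OC[C@@H](Cn2cc(Cn3c4c(c5ccccc53)C(=O)c3c[n+]([O-])c5ccccc5c3C4=O)nn2)O1`, gives 450 nM. Compound 3, `CN1CCN(CCCn2c3c(c4ccccc42)C(=O)c2c[n+]([O-])c4ccccc4c2C3=O)CC1`, gives 470 nM. Compound 1 has the highest number of the three, but its gaps to compound 3 and to compound 2 both lie within the scatter of repeated measurements, so the three cannot be told apart on these numbers. The change from compound 1 to compound 3 shortens the chain that carries the 4-methylpiperazin-1-yl group, and it gives a 1.3-fold lower number from compound 1 to compound 3 (0.13 log units; within the scatter).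

Compound 4, `CCCN1CCN(CCCCn2c3c(c4ccccc42)C(=O)c2c[n+]([O-])c4ccccc4c2C3=O)CC1`, has not yet been measured. It differs from compound 1 as follows: 4-propylpiperazin-1-yl in place of 2-(4-methylpiperazin-1-yl)ethyl on a saturated chain carbon, four bonds along the chain from an aromatic nitrogen. The atoms are the same; the chain between the core and the piperazine ring is shortened while the methyl on the piperazine is lengthened to propyl. For the measured compounds named here, the only measured step that bears on this, a 1.3-fold lower number from compound 1 to compound 3 (0.13 log units; within the scatter), shows that trimming this chain changed little. The expected step for compound 4 is therefore a 1.1-fold lower number from compound 1 to compound 4 (0.06 log units; within the scatter), nothing beyond the scatter, with an estimated value of 550 nM and a range from 250 nM to 1300 nM.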

Compound 4, half-maximal inhibitory concentration: 870 nM
Compound 4: the middle estimate sits 1.6-fold (0.20 log units) below what was measured, within the range that was stated.
By their numbers in this assay, from the lowest: compounds 2, 3, 1 and 4 (each within the scatter of the next).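

Placing 4-propylpiperazin-1-yl on the chain, with the same atoms as compound 1 joined differently, gives a 1.4-fold higher number from compound 1 to compound 4 (0.14 log units; within the scatter) in this assay and so stays within the scatter. Changing the chain and the group on the piperazine together gives a 1.9-fold higher number from compound 3 to compound 4 (0.27 log units; within the scatter) and also stays within the scatter, so the position has so far tolerated both kinds of change without a readable shift. No measurement at hand explains these numbers.

Going by these compounds, the effect of the propyl group on its own, at a fixed chain, stays open. So does whether a different group at the chain end, such as a morpholine, a primary amine or a carboxylic acid, would move the number beyond the scatter.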